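This account rests on a few compounds, and the source may have more. Where it says the series, first, only, none or still open, it means among the compounds named here.

In an ADME assay on MDBK cells (Bos taurus) for cytotoxicity, read by MTT assay, with a stated time of 96 h (a higher number here means that more compound is tolerated, a lower number that less compound is tolerated), only limits are known so far for this series. Compound 1 `C/C(=N\NC(N)=O)c1ccc2[nH]c(-c3ccc(Cl)cc3)nc2c1` gives > 100000 nM, which is a limit of the assay and not a number. Compound 2 `C/C(=N\NC(N)=O)c1ccc2c(c1)nc(-c1ccccc1)n2C1CCCCC1` gives > 100000 nM, again a limit, so its place is shared with the other measured compound: the limit of > 100000 nM in this assay, at which 2 of the 2 values shown sit. Compound 3 `C/C(=N\NC(N)=O)c1ccc2c(c1)nc(-c1ccc(Cl)cc1)n2C1CCCCC1` differs from compound 2 in one place, (chloro in place of hydrogen on an aromatic carbon), with chloro in place of hydrogen on an aromatic carbon, turning phenyl into 4-chlorophenyl. Among the measured compounds shown here, no measured pair isolates this change. Compound 1 already carries the 4-chlorophenyl group and gives > 100000 nM, a limit, and the expectation rests on that. The expected change, an at least 1.1-fold lower number from compound 2 to compound 3 (0.07 log units; that floor lies within the scatter), is none beyond the usual scatter, with any shift towards less compound tolerated. For compound 3 the estimated value is 85000 nM, within an expected range of 30000 nM to 100000 nM.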

Compound 3, half-maximal cytotoxic concentration: > 100000 nM
Compound 3 gave a limit, no number (the forecaster's own chance of this, stated with the estimate: 65%); middle value at least 1.1-fold (0.07 log units) from the limit.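

Like compound 1 and compound 2, compound 3 gives only a limit in this assay, so neither step to compound 3 can be read: the limit of > 100000 nM in this assay, at which 3 of the 3 values shown sit. The compounds shown leave open what values lie behind these limits and whether the chloro or cyclohexyl change shifts them.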